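The compounds below may be only part of what the source reports. "The series", "measured", "known", "first", "only" and "open" are said of these compounds alone.

Among the compounds with values here, compound 1, `CCn1nc(CC(=O)Nc2ccc(OC(F)(F)F)c(Cl)c2)c2ccccc2c1=O`, is the only member of this small set with a numerical result: in a functional assay on CHO cells for antagonist activity at sphingosine 1-phosphate receptor 2 (Homo sapiens), read by calcium flux (a lower number here means a stronger inhibitor, a higher number a weaker inhibitor), compound 1 gives 199 nM. Compound 2, `COc1ccc(Cl)cc1NC(=O)Cc1nn(CC(=O)O)c(=O)c2ccccc12`, reaches only a limit in this assay, > 1790 nM. Compound 3, `CCOc1cc2nn(Cc3nn(CC(=O)O)c(=O)c4ccccc34)cc2cc1Cl`, likewise yields a limit, > 6640 nM. The step of interest leads from compound 1 to compound 4, `O=C(Cc1nn(CC(=O)N2CCOCC2)c(=O)c2ccccc12)Nc1ccc(OC(F)(F)F)c(Cl)c1`, where the change is (morpholin-4-yl)carbonyl in place of methyl on a saturated chain carbon bound to an aromatic nitrogen. Within the data shown here, no measured pair isolates this change, so the size of the step can only be expected: the shared core and the anilide part of compound 1 are kept, and a modest step, likely no more than a little beyond the scatter and toward weaker inhibition, is expected, a 1.6-fold higher number from compound 1 to compound 4 (0.21 log units; within the scatter). Compound 4 is accordingly estimated at 320 nM in this assay, within 100 nM to 1000 nM.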

Compound 4, half-maximal inhibitory concentration: 30 nM
Beside the measured number, compound 4's estimate is 11-fold (1.03 log units) above it, outside the stated range (below it).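

Within the data shown here, the step gives the first reading at this position that isolates a single change: in this assay, (morpholin-4-yl)carbonyl in place of methyl on a saturated chain carbon bound to an aromatic nitrogen gives a 6.6-fold lower number from compound 1 to compound 4 (0.82 log units; beyond the scatter). A much larger group with a ring is therefore accepted here, and inhibition is stronger with it. Nothing among the data shown speaks to the cause of this step. The compounds shown leave open whether the step depends on the morpholine ring or on the carbonyl alone. A piperidin-1-ylcarbonyl or a dimethylaminocarbonyl group at this place, with the anilide part of compound 4 kept, would separate the two.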